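The source may hold more compounds than are shown below. What is called first, only, known or untested is meant among the compounds shown, and "the series" means these compounds.

Compound 1, `Cc1cc(CN/C(S)=N/Cc2ccc(NS(C)(=O)=O)cc2)c(COC(=O)C(C)(C)C)cc1C`, in a functional assay for inhibition of Vanilloid receptor (Rattus norvegicus) (a higher number here means a weaker inhibitor, a lower number a stronger inhibitor), gives 70000 nM.
Compound 2, `CCCOc1cc(C(C)(C)C)ccc1C/N=C(\S)NCc1ccc(NS(C)(=O)=O)cc1`, in this assay gives 250 nM.

Of these two numbers compound 2 has the lower one, and its gap to compound 1 lies far beyond the scatter of repeated measurements, so compound 2 is the clearly stronger inhibitor of the pair. Compound 3, `CC(C)Oc1cc(C(C)(C)C)ccc1C/N=C(\S)NCc1ccc(NS(C)(=O)=O)cc1`, is made from compound 2 by one rearrangement: isopropyl in place of propyl on an oxygen on an aromatic ring. The two compounds contain the same atoms, joined differently. Going by the values given here, no measured pair in this set shows what such a rearrangement does in this assay, so the expectation can rest only on the small size of the change and on the number for compound 2. The expected step is small, within the scatter, in no clear direction: a 1.2-fold higher number from compound 2 to compound 3 (0.08 log units; within the scatter). Compound 3 is estimated at 300 nM, most likely between 100 nM and 900 nM.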

Compound 3, half-maximal inhibitory concentration: 350 nM
For compound 3 the middle estimate is 1.2-fold (0.07 log units) below the measured one; the range from low to high includes it.
By their numbers in this assay, from the lowest: compounds 2 and 3 (each within the scatter of the next); then compound 1.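

Going by these compounds alone, putting isopropyl in place of propyl on an oxygen on an aromatic ring gives a 1.4-fold higher number from compound 2 to compound 3 (0.15 log units; within the scatter) in this assay, the first comparison here between compounds that differ in only one place. Within the scatter of repeated measurements, compound 2 and compound 3 cannot be told apart, so at this position the assay does not distinguish the straight propoxy group from the branched isopropoxy group. No measurement is available here that would explain this result.

These two groups both have 3 carbons, so the pair says nothing about how a longer chain such as hexyl, or a much smaller group such as methyl, would fare on the same oxygen. From the compounds shown here alone, whether a chain ending in an amine or a carboxylic acid would be accepted there also remains open.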